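Replacing methoxy with methylsulfanyl in compound 2

The source may report more compounds than this note shows. Statements on the series, on what has been measured and on what is new or still open speak of the compounds shown alone.

Of the compounds shown here, two have so far been tested in a functional assay on HT-29 cells (Homo sapiens) for inhibition, read by sulforhodamine B assay, with a stated time of 72 h; on this read-out higher numbers stand for weaker inhibition and lower numbers for stronger inhibition. In this test, compound 1 `C=CC1C(=O)N(c2cc(OC)c(OC)c(OC)c2)C1c1ccc(SC)cc1` gives 113 nM. Compound 2 `COc1ccc(C2C(C3CC3)C(=O)N2c2cc(OC)c(OC)c(OC)c2)cc1` gives 107 nM, which places it level with compound 1, as the two values lie within the usual scatter of each other.

Compound 3 `COc1cc(N2C(=O)C(C3CC3)C2c2ccc(SC)cc2)cc(OC)c1OC` has not yet been measured. It departs from compound 2 by a single change, methylsulfanyl in place of methoxy on an aromatic carbon, para to a large group, so that 4-methoxyphenyl becomes 4-(methylsulfanyl)phenyl. Among the measured compounds shown here, no measured pair isolates this exchange, so the data give no direct size for it. For the measured compounds named here, the only guide is that the 4-(methylsulfanyl)phenyl group already occurs in compound 1, at 113 nM. On that basis, no step beyond the scatter is expected in this assay, and neither direction is favoured. The expected change is a 1.1-fold lower number from compound 2 to compound 3 (0.03 log units; within the scatter). For compound 3, the estimated value is 100 nM, with an expected range of 40 nM to 250 nM.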

Compound 3, half-maximal inhibitory concentration: 204 nM
Compound 3: middle estimate off by 2.0-fold (0.31 log units), on the low side, within the range that was stated.
By their numbers in this assay, from the lowest: compounds 2, 1 and 3 (each within the scatter of the next).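

In this assay the exchange of methoxy for methylsulfanyl on an aromatic carbon, para to a large group, now has a measured size of a 1.9-fold higher number from compound 2 to compound 3 (0.28 log units; within the scatter) and so, with cyclopropyl on the saturated ring carbon, 4-(methylsulfanyl)phenyl and 4-methoxyphenyl are not told apart by this test. The saturated ring carbon also gets its first reading, as cyclopropyl in place of vinyl, with 4-(methylsulfanyl)phenyl held in common, gives a 1.8-fold higher number from compound 1 to compound 3 (0.26 log units; within the scatter) and thus no step beyond the scatter either. No measurement at hand bears on either step, so the data offer no explanation for their size.

The compounds shown leave open whether a different group on this aromatic carbon, such as an amine, a hydroxyl or a longer chain like ethoxy, would give a step beyond the scatter. They also leave open whether the exchange of methoxy for methylsulfanyl reads the same when vinyl rather than cyclopropyl sits on the saturated ring carbon.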